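Phenyl to Thiophene at the Chain Carbon: Expected Outcome

The source may report more compounds than this note shows. Statements on the series, on what has been measured and on what is new or still open speak of the compounds shown alone.

Three compounds have been measured in an assay on CHO cells for displacement of a labelled ligand from adenosine receptor A1 (Homo sapiens), read by scintillation counting; on this read-out higher numbers stand for weaker inhibition and lower numbers for stronger inhibition:

Compound 1 `CCSCCn1c(=O)n(CC)c(=O)c2[nH]c(-c3ccccc3)nc21`: 148 nM
Compound 2 `CCn1c(=O)c2[nH]c(Cc3ccco3)nc2n(Cc2cccs2)c1=O`: 407 nM
Compound 3 `CCn1c(=O)c2c(nc(Cc3cccs3)n2C)n(Cc2ccccc2)c1=O`: 389 nM

Compound 3 gives the second highest of these three numbers. Compound 2 gives a number within the scatter of it, so the two cannot be told apart. Compound 1 gives a lower number, and that gap lies beyond the scatter.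

Compound 4 `CCn1c(=O)c2c(nc(Cc3cccs3)n2C)n(Cc2cccs2)c1=O` has not yet been measured in this assay. It differs from compound 3 in one place: thiophen-2-yl in place of phenyl on a saturated chain carbon bound to an aromatic nitrogen. Within the data shown here, no measured pair shows this change on its own. Compound 2 also carries a (thiophen-2-yl)methyl group rather than benzyl, yet it differs from compound 3 in a further place as well, so its number only hints that such a swap need not move the result much.

The step is therefore expected to be a 1.1-fold lower number from compound 3 to compound 4 (0.05 log units; within the scatter), that is, nothing beyond the scatter in either direction. Compound 4 is estimated at 350 nM, with a range from 150 nM to 800 nM.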

Compound 4, inhibition constant: 95.5 nM
Estimate against measurement, compound 4: 3.7-fold (0.56 log units) above, outside the stated range (below it).
By their numbers in this assay, from the lowest: compounds 4 and 1 (each within the scatter of the next); then compounds 3 and 2 (each within the scatter of the next).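

In this assay, among these compounds, putting thiophen-2-yl in place of phenyl on a saturated chain carbon bound to an aromatic nitrogen gives a 4.1-fold lower number from compound 3 to compound 4 (0.61 log units; beyond the scatter) and so shows, for the first time with this change on its own, that the ring at this position affects the result. The step is modest but lies beyond the scatter, so the two rings are not interchangeable here, and the five-membered sulfur ring gives the stronger inhibition. No available evidence explains why this swap has this effect.

As far as these compounds go, this is a single pair on one background, so it remains open whether the same swap would give a similar step with other groups elsewhere on the shared core. From the compounds shown here alone, it is also open how a pyridin-2-yl ring, a cyclohexyl ring or a longer chain such as 2-phenylethyl would fare at this position.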